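From compound 1 to compound 3: a larger side group

The source may report more compounds than this note shows. Statements on the series, on what has been measured and on what is new or still open speak of the compounds shown alone.

compound 1 `CC(=O)Nc1nc2ccc(-c3cccc(C(=O)Nc4cccc(C(F)(F)F)c4)c3)nc2s1`: > 10000 nM
compound 2 `O=C(Nc1cccc(C(F)(F)F)c1)c1cccc(-c2ccc3nc(NC(=O)C4CCNCC4)sc3n2)c1`: > 10000 nM

In an ADME assay on BaF3 cells (Mus musculus) for cytotoxicity (a lower number here means that less compound is needed, a higher number that more compound is needed for the effect), compound 1 gives > 10000 nM, which is a limit of the assay and not a number. Compound 2 gives > 10000 nM, which is also a limit. The whole record so far is the limit of > 10000 nM in this assay, at which 2 of the 2 values shown sit.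

Compound 3 `CCN1CCN(Cc2ccc(NC(=O)c3cccc(-c4ccc5nc(NC(C)=O)sc5n4)c3)cc2C(F)(F)F)CC1` keeps the core of compound 1 and changes in one place: (4-ethylpiperazin-1-yl)methyl in place of hydrogen on an aromatic carbon. The (4-ethylpiperazin-1-yl)methyl group replaces a hydrogen on a six-membered aromatic ring of carbon only, ortho to a trifluoromethyl group.

Within the data shown here, only one measured step bears on this: a step that the two limits leave unreadable from compound 1 to compound 2. It lies at a different place in the molecule, and it offers no size to carry over. The direction is therefore a cautious guess: a modest move towards less compound being needed in this assay, with another limit quite possible. The expected step is an at least 1.6-fold lower number from compound 1 to compound 3 (0.22 log units; that floor lies within the scatter). For compound 3 the estimate is 6000 nM, with an expected range from 2000 nM to 10000 nM.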

Compound 3, half-maximal effective concentration: 4160 nM
Beside the measured number, compound 3's estimate is 1.4-fold (0.16 log units) above it; the measured number falls inside the stated range.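

In this assay the (4-ethylpiperazin-1-yl)methyl group, placed on an aromatic carbon ortho to a trifluoromethyl group, brings an at least 2.4-fold lower number from compound 1 to compound 3 (0.38 log units; beyond the scatter). The value of compound 1, > 10000 nM, is a limit of the assay and not a number, so the size of this step is only a floor and the real change may be larger. Compound 3 is the only one of the three compounds with a measured number, which makes this aromatic carbon the first place in the series where a change can be read at all: the limit of > 10000 nM in this assay, at which 2 of the 3 values shown sit.

Still open, as far as these compounds go, is whether this particular ring matters or whether a smaller amine, such as a dimethylaminomethyl group, or a morpholin-4-ylmethyl group on the same carbon would move the number just as far. Also open, from the compounds shown here alone, is how the number would respond to a longer chain linking the piperazine to the aromatic ring, or to a plain hydrogen in place of the ethyl group on the piperazine.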